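The source may report more compounds than this note shows. Statements on the series, on what has been measured and on what is new or still open speak of the compounds shown alone.

Measured so far:
compound 1 `CCn1c(SCC(=O)Nc2ccc(C(C)=O)cc2)nnc1-c1cc(OC)c(OC)c(OC)c1` — 64%
compound 2 `COc1cc(-c2nnc(SCC(=O)Nc3ccc(C(C)=O)cc3)n2-c2ccccc2)cc(OC)c1OC` — 63%

In a functional assay on the whole organism (strain albino) for inhibition, with Rattus norvegicus as the target, read by paw edema, with stated times of 30 min and 5 h, at a dose of 0.28 mmol/kg by the oral route (on this read-out higher numbers stand for more inhibition at the one dose given (going by the name of the read-out) and lower numbers for less inhibition), compound 1 gives 64% and compound 2 gives 63%. On the numbers shown compound 2 sits together with compound 1, its only neighbour, the gap between them within the scatter. Going by the values given here, the one step measured on this part of the shared core, a number 1 percentage points lower from compound 1 to compound 2 (within the scatter), exchanged one substituent on the aromatic nitrogen for another and moved nothing beyond the scatter.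

Compound 3 `C=CCn1c(SCC(=O)Nc2ccc(C(C)=O)cc2)nnc1-c1cc(OC)c(OC)c(OC)c1` differs from compound 2 at the same position: allyl in place of phenyl on an aromatic nitrogen

Among the compounds with values here, the only step that bears on this change is a number 1 percentage points lower from compound 1 to compound 2 (within the scatter), which was within the scatter, so for this assay no step beyond the scatter is expected in either direction. The value of compound 3 in this assay is estimated at 63%, within a range of 52% to 74%. This estimate means no change at the digits printed from compound 2 to compound 3 (within the scatter), an expected step that stays within the scatter.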

Compound 3, a percentage reported as inhibition, in the whole organism at one dose (the size of the read-out at that dose, not a potency): 64%
Compound 3: middle estimate off by 1 percentage points, on the low side; measured number inside the range.
By their numbers in this assay, from the lowest: compounds 2, 1 and 3 (each within the scatter of the next).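

In this assay the aromatic nitrogen has now carried ethyl, phenyl and allyl without any step beyond the scatter: a number 1 percentage points higher from compound 2 to compound 3 (within the scatter), and no change at the digits printed from compound 1 to compound 3 (within the scatter). The exchange of phenyl for allyl removes the six-membered aromatic ring from this place and brings in a double bond outside aromatic rings, and the read-out at the one dose given stays within the scatter, so among these compounds an aromatic ring on this nitrogen is not needed to keep it. Nothing at hand offers an explanation for this flat response.

Still open, going by these compounds, is whether the same holds for a chain ending in an amine or a carboxylic acid on this nitrogen, or for a longer chain. Because the read-out is a percentage at a single dose, it also leaves open whether these compounds would separate across a range of doses.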